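The source may hold more compounds than are shown below. What is called first, only, known or untested is meant among the compounds shown, and "the series" means these compounds.

Measured compounds:
- compound 1, `CN(C)CCCOc1c(OCc2ccccc2)cc(O)c2c(=O)cc(-c3ccccc3)oc12`: 2910 nM
- compound 2, `CCN(CC)CCCOc1c(OCc2ccccc2)cc(O)c2c(=O)cc(-c3ccccc3)oc12`: 3620 nM
- compound 3, `CN1CCN(CCCOc2c(OCc3ccccc3)cc(O)c3c(=O)cc(-c4ccccc4)oc23)CC1`: 3940 nM

All three values come from a functional assay on A549 cells (Homo sapiens) for cytotoxicity, read by MTT assay, with a stated time of 72 h; on this read-out higher numbers stand for weaker inhibition and lower numbers for stronger inhibition. The three compounds share one core and differ only in the amine at the end of the propyl chain. Compound 3 stands at one edge of the set: a 1.4-fold higher number from compound 1 to compound 3 (0.13 log units; within the scatter) and a 1.1-fold higher number from compound 2 to compound 3 (0.04 log units; within the scatter), so none of the three is separated from the others beyond the scatter, and no ranking among them can be drawn.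

Compound 4 is `CN(C)CCCCOc1c(OCc2ccccc2)cc(O)c2c(=O)cc(-c3ccccc3)oc12`. Against compound 3 the change is (dimethylamino)methyl in place of 4-methylpiperazin-1-yl on a saturated chain carbon, three bonds along the chain from an oxygen on an aromatic ring. In effect the amine head returns to the dimethylamino of compound 1 while the chain is extended by one carbon.

Among the measured compounds shown here, the steps that bear on this are the amine swaps, a 1.2-fold higher number from compound 1 to compound 2 (0.09 log units; within the scatter), a 1.4-fold higher number from compound 1 to compound 3 (0.13 log units; within the scatter) and a 1.1-fold higher number from compound 2 to compound 3 (0.04 log units; within the scatter), all within the scatter: swapping one amine for another has left this assay unchanged across the set. For the measured compounds named here, no measured pair speaks to the length of the chain, so that part of the change carries no evidence either way.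

Accordingly compound 4 is expected to sit with the others, with a 1.2-fold lower number from compound 3 to compound 4 (0.09 log units; within the scatter) amounting to no step beyond the scatter. The estimate for compound 4 in this assay is 3200 nM, with a range from 1500 nM to 7000 nM, the wider upper side reflecting the unmeasured chain extension.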

Compound 4, half-maximal inhibitory concentration: 1090 nM
The estimate for compound 4 lay 2.9-fold (0.47 log units) above the measured number, and the stated range ends above it.
By their numbers in this assay, from the lowest: compound 4; then compounds 1, 2 and 3 (each within the scatter of the next).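

Up to this point, swapping the amine at this place left this assay unchanged within the scatter, whereas the 4-(dimethylamino)butyl chain of compound 4 separates from all three propyl-linked compounds, with a 3.6-fold lower number from compound 3 to compound 4 (0.56 log units; beyond the scatter) and a 3.3-fold lower number from compound 2 to compound 4 (0.52 log units; beyond the scatter) both beyond the scatter. The cleanest reading comes from the pair that keeps the dimethylamino head, where 4-(dimethylamino)butyl stands in place of 3-(dimethylamino)propyl and the result is a 2.7-fold lower number from compound 1 to compound 4 (0.43 log units; beyond the scatter) as a modest step beyond the scatter, so this place responds to the length of the chain in a way the amine swaps never showed, on the strength of this single pair. No measurement at hand accounts for this step.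

The compounds shown leave open whether the trend carries on to a longer chain such as 5-(dimethylamino)pentyl or reverses with a shorter one such as 2-(dimethylamino)ethyl, since two chain lengths fix no optimum. They also leave open whether diethylamino and 4-methylpiperazin-1-yl stay level with dimethylamino on the butyl chain, as they do on the propyl chain.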